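The source may report more compounds than this note shows. Statements on the series, on what has been measured and on what is new or still open speak of the compounds shown alone.

Measured so far:
- compound 1 `Oc1nc2nonc2nc1Nc1ccc(S(F)(F)(F)(F)F)cc1`, in an assay on mitochondria from L6 cells (Rattus norvegicus) for activation, with a stated time of 90 min (on this read-out lower numbers stand for an effect already at smaller amounts and higher numbers for an effect only at larger amounts of compound), compound 1 gives 3900 nM
- compound 2 `Oc1nc2nonc2nc1Nc1ccc(C(F)(F)F)cc1`, in this assay compound 2 gives 10400 nM

Compound 2 has the highest number of the two measured; its nearest neighbour, compound 1, lies lower by the step of a 2.7-fold higher number from compound 1 to compound 2 (0.43 log units; beyond the scatter). Compound 3 `Oc1nc2nonc2nc1Nc1ccc(OC(F)(F)C(F)F)cc1` differs from compound 2 in one place: 1,1,2,2-tetrafluoroethoxy in place of trifluoromethyl on an aromatic carbon. The only measured step that bears on this change is the one between compound 1 and compound 2, where a larger fluorinated group on the same aromatic carbon gave the lower number, a modest step as shown above. Since compound 3 again carries a larger fluorinated group in that place, a modest move back toward lower numbers is expected, though a new group of this kind could also leave the value within the scatter. For compound 3 the expected change is a 1.7-fold lower number from compound 2 to compound 3 (0.24 log units; within the scatter), giving an estimate of 6000 nM with a range from 2000 nM to 20000 nM.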

Compound 3, half-maximal effective concentration: 7000 nM
For compound 3 the middle estimate is 1.2-fold (0.07 log units) below the measured one; the measured number falls inside the stated range.
By their numbers in this assay, from the lowest: compounds 1, 3 and 2 (each within the scatter of the next, the first and the last beyond it).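

In this assay, putting 1,1,2,2-tetrafluoroethoxy on this aromatic carbon in place of trifluoromethyl gives a 1.5-fold lower number from compound 2 to compound 3 (0.17 log units; within the scatter) and so does not clearly shift the read-out, even though the new group brings an oxygen and a longer fluorinated chain. The comparison with the other large group gives a 1.8-fold higher number from compound 1 to compound 3 (0.25 log units; within the scatter) and so does not separate them either, which means that compound 3 cannot be told apart from compound 2 or compound 1, although those two differ beyond the scatter. Nothing measured here explains these results.

The compounds shown leave open whether fluorine is needed at this place, as a plain ethoxy group would test. They also leave open how an amine or a carboxylic acid on this aromatic carbon would read.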